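The source may hold more compounds than are shown below. What is called first, only, known or untested is meant among the compounds shown, and "the series" means these compounds.

The series is built around compounds that share one core. Compound 1 `Cc1ccc(S(=O)(=O)/C(=C/c2c(F)c(F)c(F)c(F)c2F)C(=O)c2ccc(Cl)cc2)cc1` carries a (4-methylphenyl)sulfonyl group on a double-bonded chain carbon bound to a carbonyl carbon and a double-bonded chain carbon. In a functional assay on DU-145 cells (Homo sapiens) for inhibition, read by trypan blue exclusion, with a stated time of 96 h (on this read-out higher numbers stand for weaker inhibition of growth and lower numbers for stronger inhibition of growth), compound 1 gives only a limit, > 100000 nM, and no number; this is the limit of > 100000 nM in this assay, at which 1 of the 3 values shown sits. Compound 2 `Cc1ccc(S/C(=C/c2c(F)c(F)c(F)c(F)c2F)C(=O)c2ccc(Cl)cc2)cc1` differs from compound 1 by (4-methylphenyl)sulfanyl in place of (4-methylphenyl)sulfonyl on a double-bonded chain carbon bound to a carbonyl carbon and a double-bonded chain carbon. In this assay compound 2 gives 25000 nM. That change produced an at least 4.0-fold lower number from compound 1 to compound 2 (0.60 log units; beyond the scatter).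

Compound 3 `Cc1ccc(S(=O)(=O)/C(=C/c2ccc(N(C)C)cc2)C(=O)c2ccc(Br)cc2)cc1` keeps the (4-methylphenyl)sulfonyl group, but its core differs from the core of compound 1 in a way that is not broken down here. In this assay compound 3 gives 50000 nM. Going by the values given here, compound 4 `Cc1ccc(S/C(=C/c2ccc(N(C)C)cc2)C(=O)c2ccc(Br)cc2)cc1` has not yet been measured in this assay; it differs from compound 3 by (4-methylphenyl)sulfanyl in place of (4-methylphenyl)sulfonyl on a double-bonded chain carbon bound to a carbonyl carbon and a double-bonded chain carbon, which is the same change, made at the same place, as the one that separates compound 1 from compound 2, so that this change occurs two times among the compounds described.

Among the compounds with values here, since the one measured instance of this change gave an at least 4.0-fold lower number from compound 1 to compound 2 (0.60 log units; beyond the scatter), the expectation for compound 4 rests on that step, with the reading of compound 3 as its starting point. Compound 4 is therefore expected to show a 4.0-fold lower number from compound 3 to compound 4 (0.60 log units; beyond the scatter). Compound 4 is estimated at 12500 nM in this assay, with a likely span from 4000 nM to 40000 nM.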

Compound 4, concentration for 50% growth inhibition: > 100000 nM
Compound 4: only a limit was reported (the forecaster's own chance of this, stated with the estimate: 5%); middle value at least 8.0-fold (0.90 log units) away from the limit.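

In this assay compound 4 gives > 100000 nM, which is a limit and not a number. Putting (4-methylphenyl)sulfanyl in place of (4-methylphenyl)sulfonyl on the core of compound 3 therefore gives an at least 2.0-fold higher number from compound 3 to compound 4 (0.30 log units; that floor lies within the scatter), a floor rather than a measured size, and this same change does not read alike on the two cores: the same change on two cores in this assay, an at least 4.0-fold lower number (0.60 log units; beyond the scatter) from compound 1 to compound 2 and an at least 2.0-fold higher number (0.30 log units; that floor lies within the scatter) from compound 3 to compound 4, at least 8.0-fold (0.90 log units) apart, beyond the scatter of two such steps. Going by these compounds alone, this shows that the result from one core could not be carried over to the other, but it does not give the true size of either step or show what makes the cores differ, and with only two pairs it sets no rule for any further core, as compound 1 and compound 4 both leave a step with one end at a limit: the limit of > 100000 nM in this assay, at which 2 of the 4 values shown sit.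

The compounds shown leave open which of the places where the core of compound 3 differs from the core of compound 1 decides the outcome, as no pair here separates those places. They also leave open how a (4-methylphenyl)sulfinyl group or a methoxy group would read on that same double-bonded chain carbon on either core.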